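Swapping the chain terminus of an anilinoquinoline carboxamide series

The source may report more compounds than this note shows. Statements on the series, on what has been measured and on what is new or still open speak of the compounds shown alone.

Compound 3, with structure `CN(C)CCCNc1c(C(=O)NCc2ccc(F)cc2)nc(Br)c2cccnc12`, carries a 3-(dimethylamino)propyl group on a nitrogen of the shared core. In a functional assay on LNCaP cells (Homo sapiens) for cytotoxicity, read by MTT assay, with a stated time of 72 h (on this read-out lower numbers stand for stronger inhibition and higher numbers for weaker inhibition), compound 3 gives 8000 nM. Compound 1, `Nc1cccc(Nc2c(C(=O)NCc3ccc(F)cc3)nc(Br)c3cccnc23)c1`, bears a 3-aminophenyl group in the same place, and in this assay compound 1 gives 8000 nM. The step of no change at the digits printed from compound 1 to compound 3 (within the scatter) therefore shows that exchanging these two very different groups left the read-out unmoved. Compound 2, `NCCCNc1c(C(=O)NCc2ccc(F)cc2)nc(Br)c2cccnc12`, has a plain 3-aminopropyl chain; for compound 2 the result in this assay is "not determined" (no result reported), so it adds nothing to the comparison.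

Compound 4, `O=C(NCCCNc1c(C(=O)NCc2ccc(F)cc2)nc(Br)c2cccnc12)c1ccccc1`, differs from compound 3 as follows: benzamido in place of dimethylamino on a saturated chain carbon, three bonds along the chain from a nitrogen on an aromatic ring. For the measured compounds named here, the only step that bears on this change is the one from compound 1 to compound 3, which was flat, and it concerns the same position on the core. Compound 4 is expected to stay level, with no change at the digits printed from compound 3 to compound 4 (within the scatter) lying within the scatter. Compound 4 is accordingly estimated at 8000 nM, with a likely range of 3000 nM to 20000 nM.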

Compound 4, half-maximal inhibitory concentration: > 10000 nM
Compound 4: only a limit was reported; the forecaster's own chance of this, stated with the estimate: 20%; middle value at least 1.2-fold (0.09 log units) away from the limit.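

For compound 4, the > 10000 nM in this assay is a limit of the assay and not a number. Where the earlier step compared groups on a nitrogen of the shared core, this one changes the end of the chain, and it gives an at least 1.2-fold higher number from compound 3 to compound 4 (0.09 log units; that floor lies within the scatter), so replacing dimethylamino with benzamido, which brings in a six-membered aromatic ring, shows no stronger inhibition at this chain end. The size of the step cannot be read past that floor, for this reason: the limit of > 10000 nM in this assay, at which 1 of the 4 values shown sits.

The compounds shown leave open whether a carboxylic acid or a morpholine at the end of this chain, or a longer chain, would move the read-out relative to compound 3 at 8000 nM. On these data alone, compound 2 has no reported result, so the effect of the plain 3-aminopropyl chain also stays unknown.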